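A Bromine for a Fluorine on the Sulfonyl Ring

The source may hold more compounds than are shown below. What is called first, only, known or untested is meant among the compounds shown, and "the series" means these compounds.

Of the compounds shown here, three sharing one core have been measured in a functional assay on HCC1806 cells (Homo sapiens) for inhibition, read by sulforhodamine B assay, tested at 10 uM; on this read-out lower numbers stand for less inhibition and higher numbers for more inhibition at the one concentration tested (going by the name of the read-out). Compound 1 `COC(=O)CC(=O)N1N=C(c2ccc(-n3cncn3)cc2)CC1c1ccc(N(C)C)cc1` gives -7.8%. Compound 2 `CN(C)c1ccc(C2CC(c3ccc(-n4cncn4)cc3)=NN2S(C)(=O)=O)cc1` gives 10.8%, and compound 3 `CN(C)c1ccc(C2CC(c3ccc(-n4cncn4)cc3)=NN2S(=O)(=O)c2ccc(F)cc2)cc1` gives 24.1%, the highest of the three; its nearest neighbour is compound 2, and compound 1 stands furthest away. The steps leading up to it were a number 31.9 percentage points higher from compound 1 to compound 3 (beyond the scatter) and a number 13.3 percentage points higher from compound 2 to compound 3 (beyond the scatter), while a number 18.6 percentage points higher from compound 1 to compound 2 (beyond the scatter) links the two lower compounds.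

Compound 4 `CN(C)c1ccc(C2CC(c3ccc(-n4cncn4)cc3)=NN2S(=O)(=O)c2ccc(Br)cc2)cc1` is not yet measured. Its change from compound 3 is bromo in place of fluoro on an aromatic carbon. Among the measured compounds shown here, none of the measured steps touches a halogen on this ring; the only one that reaches the aryl sulfonyl at all, a number 13.3 percentage points higher from compound 2 to compound 3 (beyond the scatter), put 4-fluorophenyl in place of methyl on the sulfonyl sulfur rather than altering a substituent on that ring. Without a step of its kind to lean on, the expected step in this assay, a number 3.9 percentage points higher from compound 3 to compound 4 (within the scatter), is small and not beyond the scatter, with only a slight lean upward. Compound 4 is therefore estimated at 28%, within 10% to 46%.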

Compound 4, a percentage reported as inhibition, at one concentration (the size of the read-out at that concentration, not a potency): 26.3%
Compound 4: middle estimate off by 1.7 percentage points, on the high side; low and high end bracket the measured number.
By their numbers in this assay, from the lowest: compound 1; then compound 2; then compounds 3 and 4 (each within the scatter of the next).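

In this assay, among the compounds shown here, the halogen on the sulfonyl ring was changed for the first time, para to a large group, and the result was a number 2.2 percentage points higher from compound 3 to compound 4 (within the scatter), so at this position the assay does not separate bromo from fluoro. The rise that came with the aryl sulfonyl also holds with the heavier halogen, as seen in a number 15.5 percentage points higher from compound 2 to compound 4 (beyond the scatter) and in a number 34.1 percentage points higher from compound 1 to compound 4 (beyond the scatter), so it does not depend on fluoro alone. No evidence accompanies these compounds to say why the two halogens read alike.

On these data alone, what remains open is whether a halogen matters here at all, which a plain phenyl on the sulfonyl, or a methoxy or an amine at the same place, would answer. Whether a different position on this ring would respond differently also stays unsettled.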